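The source may report more compounds than this note shows. Statements on the series, on what has been measured and on what is new or still open speak of the compounds shown alone.

Measured so far in a functional assay on NUGC-3 cells (Homo sapiens) for antiproliferative activity, read by sulforhodamine B assay; a lower number here means a stronger inhibitor of growth, a higher number a weaker inhibitor of growth:

compound 1 (`O=C(/C=C/c1ccc(O)cc1)c1c(O)cccc1OCCC1CCCCC1`): > 30000 nM
compound 2 (`CCCCOc1cccc(O)c1C(=O)/C=C/c1ccc(O)cc1`): > 30000 nM

Compound 2 stands at > 30000 nM, and this is a limit, not a number. Both measured compounds sit at the same point, (the limit of > 30000 nM in this assay, at which 2 of the 2 values shown sit), so compound 2 has no numerical place in the series.

The next compound is compound 3 (`CC(C)CCOc1cccc(O)c1C(=O)/C=C/c1ccc(O)cc1`). Its difference from compound 2 is methyl in place of hydrogen on a saturated chain carbon bound to two saturated chain carbons. In words, this is methyl in place of hydrogen on a saturated chain carbon bound to two saturated chain carbons, the same difference as butyl to isopentyl.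

Among the measured compounds shown here, one measured step bears on this change, as it also alters the chain: a step that the two limits leave unreadable from compound 1 to compound 2. That step has no readable size, so it offers no measure for the new change. Neither chain gives a readable value in this assay, so no step beyond the scatter is expected, and a further limit is the likeliest report.

The expected step is an at least 1.0-fold lower number from compound 2 to compound 3 (0.02 log units; that floor lies within the scatter).

For compound 3 the estimated value is 28000 nM, with an expected range from 12000 nM to 40000 nM.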

Compound 3, concentration for 50% growth inhibition: 12400 nM
For compound 3 the middle estimate is 2.3-fold (0.35 log units) above the measured one, within the range that was stated.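

In this assay, methyl in place of hydrogen on a saturated chain carbon bound to two saturated chain carbons gives the series its first readable value, with an at least 2.4-fold lower number from compound 2 to compound 3 (0.38 log units; beyond the scatter). The comparison with the cyclohexyl chain gives an at least 2.4-fold lower number from compound 1 to compound 3 (0.38 log units; beyond the scatter); both steps are bounds rather than sizes, and the step between the two limit compounds cannot be read. Compound 3 is thus the only compound shown that lies off the assay limit, so this single methyl separates the isopentyl chain from the butyl chain, while the larger cyclohexyl change gives no simple trend with chain bulk, and compound 1 goes against any reading that more carbon on the chain brings stronger growth inhibition: the limit of > 30000 nM in this assay, at which 2 of the 3 values shown sit.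

As far as these compounds go, the true size of both steps remains open, and a single readable value defines no trend along the chain. Also open, from the compounds shown here alone, is whether a longer branched chain, or a chain carrying an amine or a carboxylic acid, would lower the number further or return it to the limit.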